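The source may report more compounds than this note shows. Statements on the series, on what has been measured and on what is new or still open speak of the compounds shown alone.

Compound 1 `c1ccc(C2CC(c3ccc4c(c3)OCCO4)=NN2c2ccccc2)cc1`: 22400 nM
Compound 2 `c1ccc(N2N=C(c3ccc4c(c3)OCCO4)CC2c2ccco2)cc1`: a limit, > 100000 nM
Compound 3 `c1ccc(N2N=C(c3ccc4c(c3)OCCO4)CC2c2ccc3ccccc3c2)cc1`: 13900 nM

In a functional assay on WM 266-4 cells (Homo sapiens) for antiproliferative activity, read by MTT assay, with a stated time of 24 h (on this read-out higher numbers stand for weaker inhibition of growth and lower numbers for stronger inhibition of growth), compound 1 gives the highest of the two numbers, and compound 3 sits within the scatter of it. For compound 2 the assay reports only a limit. Compound 4 `COc1ccc(C2CC(c3ccc4c(c3)OCCO4)=NN2c2ccccc2)cc1OC` differs from compound 1 by 3,4-dimethoxyphenyl in place of phenyl on a saturated ring carbon. Among the measured compounds shown here, two measured steps touch this position: an at least 4.4-fold higher number from compound 1 to compound 2 (0.64 log units; beyond the scatter), and a 1.6-fold lower number from compound 1 to compound 3 (0.21 log units; within the scatter). Only the furan-2-yl change moved the number beyond the scatter, and in the wrong direction; the naphthalen-2-yl change stayed within it. Since compound 3 gave 13900 nM, a six-membered carbon-only ring here is expected to leave the number near that of compound 1, so compound 4 is estimated at 20000 nM (6000 nM to 70000 nM), a step of a 1.1-fold lower number from compound 1 to compound 4 (0.05 log units; within the scatter).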

Compound 4, concentration for 50% growth inhibition: 2160 nM
Estimate against measurement, compound 4: 9.3-fold (0.97 log units) above; the whole stated range lies above it.
By their numbers in this assay, from the lowest: compound 4; then compounds 3 and 1 (each within the scatter of the next). At a limit, above all of these: compound 2.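

In this assay, this position proves able to lower the number beyond the scatter, which neither the furan-2-yl nor the naphthalen-2-yl change had done: 3,4-dimethoxyphenyl gives a 10-fold lower number from compound 1 to compound 4 (1.02 log units; beyond the scatter) and a 6.4-fold lower number from compound 3 to compound 4 (0.81 log units; beyond the scatter), so naphthalen-2-yl does not match it. Against furan-2-yl the step is an at least 46-fold lower number from compound 2 to compound 4 (1.66 log units; beyond the scatter). That step rests on compound 2, whose value is only a limit: the limit of > 100000 nM in this assay, at which 1 of the 4 values shown sits.

The compounds shown leave open whether both methoxy groups are needed, or whether a single methoxy group, a hydroxyl or an amine on the phenyl would serve as well.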